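Trading dipropylamino for (3-fluorophenyl)amino on the shared core

A few compounds are considered here, and "the series" means these few. Any claim that something is new, unique, unknown or untested is made for them only; others in the source may bear on it.

Compound 3 `CCCN(CCC)C1=CC(=O)c2c(nc3n2[C@H]2OC[C@@H](O)[C@H]2OC3)C1=O` carries a dipropylamino group on the shared core. In a functional assay on ECa-109 cells for inhibition, with ECa-109 cell line (Homo sapiens) as the target, read by sulforhodamine B assay (a higher number here means a weaker inhibitor, a lower number a stronger inhibitor), compound 3 gives > 16000 nM and that is a limit, not a number. Compound 2 `COc1ccc(NC2=CC(=O)c3c(nc4n3[C@H]3OC[C@@H](O)[C@H]3OC4)C2=O)cc1` has (4-methoxyphenyl)amino in the same place and gives 3410 nM in this test. Compound 1 `COc1ccccc1NC1=CC(=O)c2c(nc3n2[C@H]2OC[C@@H](O)[C@H]2OC3)C1=O` has (2-methoxyphenyl)amino there and gives > 4000 nM and this too is a limit.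

Compound 4 `O=C1C(Nc2cccc(F)c2)=CC(=O)c2c1nc1n2[C@H]2OC[C@@H](O)[C@H]2OC1` has not been measured. Its difference from compound 3 is (3-fluorophenyl)amino in place of dipropylamino on a double-bonded ring carbon and the change brings in one six-membered aromatic ring and a hydrogen-bond donor.

The closest guide is an at least 4.6-fold higher number from compound 2 to compound 3 (0.67 log units; beyond the scatter) and this step runs opposite to the one at issue, replacing an arylamino group with dipropylamino. The step that the two limits leave unreadable from compound 1 to compound 3 adds nothing readable. The step of an at least 1.1-fold lower number from compound 1 to compound 2 (0.06 log units; that floor lies within the scatter) shows no clear effect of moving the methoxy group, though it says nothing about fluorine.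

Read in reverse, the step from compound 2 suggests a lower number, so the estimated change is an at least 4.0-fold lower number from compound 3 to compound 4 (0.60 log units; beyond the scatter) as an expectation only. For compound 4 the estimate is 4000 nM with an expected range of 1200 nM to 13000 nM in this assay when it is tested.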

Compound 4, half-maximal inhibitory concentration: 2370 nM
Estimate against measurement, compound 4: 1.7-fold (0.23 log units) above, and the stated range covers the measured number.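

The swap from dipropylamino to an arylamino group now has a second example in this assay, this time with a fluorinated ring: an at least 6.7-fold lower number from compound 3 to compound 4 (0.82 log units; beyond the scatter), so the gain seen with the 4-methoxyphenyl group in compound 2 is not unique to that group. The identity of the aryl group makes no clear difference among the compounds that can be compared: a 1.4-fold lower number from compound 2 to compound 4 (0.16 log units; within the scatter), and the other comparison gives an at least 1.6-fold lower number from compound 1 to compound 4 (0.22 log units; that floor lies within the scatter), so neither step separates the 3-fluorophenyl group from a methoxyphenyl group. Compound 3 has only a limit in this test, which means that the step from it has a floor and no exact size: the limit of > 16000 nM in this assay, at which 1 of the 4 values shown sits.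

Compound 1 also has only a limit, and how far the 2-methoxyphenyl group truly lies from the other aryl groups stays open: the limit of > 4000 nM in this assay, at which 1 of the 4 values shown sits. The change from dipropylamino brings in the aromatic ring and the hydrogen-bond donor together, and the compounds shown do not tell which of the two matters; a propylamino group, which keeps the hydrogen on the nitrogen but has no ring, would pull them apart.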